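Compound 2 and its stereo-defined form, compound 3

A few compounds are considered here, and "the series" means these few. Any claim that something is new, unique, unknown or untested is made for them only; others in the source may bear on it.

Compound 1 `COc1cc(C2Oc3cc([C@H]4Oc5cc(O)cc(O)c5C(=O)[C@@H]4O)ccc3OC2CO)ccc1OC(=O)c1cc(O)c(O)c(O)c1`: 10400 nM
Compound 2 `COc1cc(C2Oc3cc([C@H]4Oc5cc(OC(=O)c6cc(O)c(O)c(O)c6)cc(O)c5C(=O)[C@@H]4O)ccc3OC2CO)ccc1O`: 4750 nM

In a functional assay on HUVEC cells (Homo sapiens) for inhibition, read by MTT assay, with a stated time of 3 days (a lower number here means a stronger inhibitor, a higher number a weaker inhibitor), compound 2 stands lowest at 4750 nM, and the gap to compound 1 lies beyond the usual scatter. Compound 3 `COc1cc([C@@H]2Oc3cc([C@H]4Oc5cc(OC(=O)c6cc(O)c(O)c(O)c6)cc(O)c5C(=O)[C@@H]4O)ccc3O[C@H]2CO)ccc1O` has the same atoms and bonds as compound 2, and the only difference is the two compounds have the same atoms and bonds; at least one stereo element is drawn with a configuration in one of them and without one in the other: 2 of 4 stereo elements differ; a stereocentre at a saturated ring carbon is drawn without a configuration in compound 2 and S in compound 3; a stereocentre at a saturated ring carbon is drawn without a configuration in compound 2 and S in compound 3. For the measured compounds named here, no measured pair shows a change of this kind, so no step beyond the scatter is expected in this assay. The estimate is a 1.1-fold lower number from compound 2 to compound 3 (0.02 log units; within the scatter). For compound 3 the estimated value is 4500 nM, with an expected range of 2200 nM to 9000 nM.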

Compound 3, half-maximal inhibitory concentration: 4290 nM
Estimate against measurement, compound 3: 1.0-fold (0.02 log units) above; low and high end bracket the measured number.
By their numbers in this assay, from the lowest: compounds 3 and 2 (each within the scatter of the next); then compound 1.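

In this assay, drawing both saturated ring stereocentres as S leaves the number within the scatter: a 1.1-fold lower number from compound 2 to compound 3 (0.04 log units; within the scatter). Compounds 1 and 2 showed nothing about configuration at these two centres, and this pair now shows compound 3 level with compound 2. The comparison is between a defined and an undefined drawing, not between two opposite configurations: the fact that one of compounds 2 and 3 is drawn with a defined configuration and the other without, at the place where they differ.

As far as these compounds go, the opposite configuration at these centres remains open. So does the effect on the number of an amine or a carboxylic acid in place of the hydroxymethyl group.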